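Cyclopropyl for methyl, carried over to the chloro core

This account rests on a few compounds, and the source may have more. Where it says the series, first, only, none or still open, it means among the compounds named here.

Compound 1 `Cc1cc(Nc2nc(NCc3ccc(F)cc3F)nc3ccc(F)cc23)n[nH]1` in an assay for inhibition of high affinity nerve growth factor receptor (Homo sapiens), read by HTRF, with a stated time of 30 min, in the presence of a further agent that is not named here (on this read-out higher numbers stand for weaker inhibition and lower numbers for stronger inhibition), gives 44 nM. Compound 2 `Fc1ccc(CNc2nc(Nc3cc(C4CC4)[nH]n3)c3cc(F)ccc3n2)c(F)c1` differs from it by cyclopropyl in place of methyl on an aromatic carbon, and in this assay compound 2 gives 59 nM, so the step is a 1.3-fold higher number from compound 1 to compound 2 (0.13 log units; within the scatter). Compound 3 `Cc1cc(Nc2nc(NCc3ccc(F)cc3F)nc3ccc(Cl)cc23)n[nH]1` carries the other change, (chloro in place of fluoro on an aromatic carbon); in this assay compound 3 gives 520 nM, and the step of a 12-fold higher number from compound 1 to compound 3 (1.07 log units; beyond the scatter) sets compound 3 apart from both compound 1 and compound 2.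

Compound 4 `Fc1ccc(CNc2nc(Nc3cc(C4CC4)[nH]n3)c3cc(Cl)ccc3n2)c(F)c1` is not yet measured. It stands to compound 3 as compound 2 stands to compound 1: cyclopropyl in place of methyl on an aromatic carbon. The place of the change is described in the same words for both pairs, so this is the same change, now made on the core of compound 3 rather than the core of compound 1.

Among the compounds with values here, from compound 3 to compound 4 a step of a 1.3-fold higher number from compound 3 to compound 4 (0.10 log units; within the scatter) is expected, beside the measured 1.3-fold higher number from compound 1 to compound 2 (0.13 log units; within the scatter), because the only step of this change on record, a 1.3-fold higher number from compound 1 to compound 2 (0.13 log units; within the scatter), lies within the scatter. Compound 4 is therefore estimated at 650 nM, with a range from 300 nM to 1400 nM.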

Compound 4, half-maximal inhibitory concentration: 72 nM
Beside the measured number, compound 4's estimate is 9.0-fold (0.96 log units) above it; the measured number lies below the stated range.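

In this assay the step for cyclopropyl in place of methyl does not carry over from one core to the other at the same size: the same change on two cores in this assay, a 1.3-fold higher number (0.13 log units; within the scatter) from compound 1 to compound 2 and a 7.2-fold lower number (0.86 log units; beyond the scatter) from compound 3 to compound 4, 9.7-fold (0.99 log units) apart, beyond the scatter of two such steps. On the chloro core the change reads a 7.2-fold lower number from compound 3 to compound 4 (0.86 log units; beyond the scatter), and with cyclopropyl in place the step for chloro in place of fluoro reads a 1.2-fold higher number from compound 2 to compound 4 (0.09 log units; within the scatter), so the large step seen between the methyl compounds does not recur between the cyclopropyl compounds: the same change on two cores in this assay, a 12-fold higher number (1.07 log units; beyond the scatter) from compound 1 to compound 3 and a 1.2-fold higher number (0.09 log units; within the scatter) from compound 2 to compound 4, 9.7-fold (0.99 log units) apart, beyond the scatter of two such steps. These four compounds show that the two changes do not add independently in this set, but they do not show why, nor how cyclopropyl for methyl would behave on any other core.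

The compounds shown leave open whether an ethyl or a tert-butyl group in place of cyclopropyl would also give a lower number on the chloro core. They also leave open whether bromo in place of chloro would follow the same pattern with methyl and with cyclopropyl.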